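A Melanoma Cell Series: From Indolyl to Aminomethoxyphenyl

This account rests on a few compounds, and the source may have more. Where it says the series, first, only, none or still open, it means among the compounds named here.

Compound 1 `COc1cc(-c2ccnc3cc(-c4c[nH]c5ccccc45)nn23)cc(OC)c1OC`: 40 nM
Compound 2 `COc1ccc(-c2cc3nccc(-c4cc(OC)c(OC)c(OC)c4)n3n2)cc1`: 1410 nM
Compound 3 `COc1ccc(-c2cc3nccc(-c4cc(OC)c(OC)c(OC)c4)n3n2)cc1F`: 3950 nM

Of the compounds shown here, three sharing one core have been measured in a functional assay on B16-F0 cells (Mus musculus) for inhibition, read by CCK-8 assay, with a stated time of 48 h; on this read-out higher numbers stand for weaker inhibition and lower numbers for stronger inhibition. Compound 1 holds the lowest number of the three; its nearest neighbour is compound 2, and the step of a 35-fold higher number from compound 1 to compound 2 (1.55 log units; beyond the scatter) lies beyond the scatter, as does the larger step of a 99-fold higher number from compound 1 to compound 3 (1.99 log units; beyond the scatter). Between the two methoxyphenyl compounds, the step of a 2.8-fold higher number from compound 2 to compound 3 (0.45 log units; beyond the scatter) is modest but still beyond the scatter.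

Compound 4 `COc1ccc(-c2cc3nccc(-c4cc(OC)c(OC)c(OC)c4)n3n2)cc1N` has not yet been tested in this assay. It differs from compound 1 in one place: 3-amino-4-methoxyphenyl in place of 1H-indol-3-yl on an aromatic carbon. Both measured steps that replace 1H-indol-3-yl with a methoxyphenyl group bear on this change, and both were large losses. Compound 4 carries an amino group where compound 3 carries fluoro, so the expectation is a loss of the same order as seen from compound 1 to compound 2 and compound 3, with the amino case left open by the data. Compound 4 is therefore expected to show a large step of a 38-fold higher number from compound 1 to compound 4 (1.57 log units; beyond the scatter), toward weaker inhibition. The estimate for compound 4 is 1500 nM, within a range of 300 nM to 6000 nM.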

Compound 4, half-maximal inhibitory concentration: 88 nM
Estimate against measurement, compound 4: 17-fold (1.23 log units) above; the whole stated range lies above it.
By their numbers in this assay, from the lowest: compound 1; then compound 4; then compound 2; then compound 3.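

In this assay, going by these compounds alone, the 3-amino-4-methoxyphenyl group nearly makes up for the loss of 1H-indol-3-yl on this aromatic carbon: the step is only a 2.2-fold higher number from compound 1 to compound 4 (0.34 log units; beyond the scatter), still beyond the scatter but far smaller than the earlier steps from the indolyl compound. Replacing the indolyl group with a methoxyphenyl group therefore need not cost much, and what sits on that phenyl ring decides the outcome, as the amino group gives a 16-fold lower number from compound 2 to compound 4 (1.20 log units; beyond the scatter) against hydrogen and a 45-fold lower number from compound 3 to compound 4 (1.65 log units; beyond the scatter) against fluoro, whereas fluoro in place of hydrogen had moved the number only modestly. Nothing available here accounts for the size of these steps, so the result stands as an observation without an explanation.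

The compounds shown leave open whether the gain is specific to the free amino group or would persist with a methylamino, a dimethylamino, an acetamide or a hydroxyl group in its place. They also leave open whether the neighbouring methoxy group is needed, a question that a 3-aminophenyl or a 3-amino-4-ethoxyphenyl group could address.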